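The source may report more compounds than this note shows. Statements on the series, on what has been measured and on what is new or still open speak of the compounds shown alone.

Measured so far:
compound 1 `O=C1C=CC(O)(c2cc3ccc(F)cc3n2S(=O)(=O)c2ccccc2)C=C1`: 20 nM
compound 2 `Cc1ccc(S(=O)(=O)n2c(C3(O)C=CC(=O)C=C3)cc3ccccc32)cc1`: 40 nM

In a functional assay on ACHN cells (Homo sapiens) for inhibition, read by MTT assay, with a stated time of 72 h (on this read-out lower numbers stand for higher toxicity in this test and higher numbers for lower toxicity in this test), compound 2 gives 40 nM, which lies within the scatter of compound 1, so the two cannot be ranked. The next compound is compound 3 `CCOC(=O)Nc1ccc(S(=O)(=O)n2c(C3(O)C=CC(=O)C=C3)cc3ccccc32)cc1`, which carries (ethoxycarbonyl)amino in place of methyl on an aromatic carbon, para to a large group: (ethoxycarbonyl)amino in place of methyl on an aromatic carbon. Within the data shown here, no measured pair differs in one place only, so the data give no direct guide to the size of this step. The two measured values offer only a baseline, and no shift beyond the scatter is expected in this assay. The estimate is a 1.3-fold higher number from compound 2 to compound 3 (0.10 log units; within the scatter), a step expected to stay within the scatter. For compound 3 the expected value is 50 nM, with an estimated range of 15 nM to 170 nM.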

Compound 3, concentration lethal to 50% of the cells: 600 nM
The estimate for compound 3 lay 12-fold (1.08 log units) below the measured number, and the stated range ends below it.
By their numbers in this assay, from the lowest: compounds 1 and 2 (each within the scatter of the next); then compound 3.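

In this assay the replacement of methyl by (ethoxycarbonyl)amino on an aromatic carbon, para to a large group, gives a 15-fold higher number from compound 2 to compound 3 (1.18 log units; beyond the scatter) and so marks this position as sensitive to the group it carries, with lower toxicity in this test for the larger group. The entering group differs from methyl in size and in its hydrogen-bond donor and acceptors, and this single step cannot separate these features. No measured data bear on the cause of this step.

From the compounds shown here alone, it remains open whether an amine, an acetamide or a longer alkoxycarbonyl chain at this position would behave like methyl or like (ethoxycarbonyl)amino. Going by these compounds, it is also open whether the same replacement would have a similar effect on a core carrying fluorine, as in compound 1.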